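Amide aryl variation on the shared core, PDE7A inhibition

The source may report more compounds than this note shows. Statements on the series, on what has been measured and on what is new or still open speak of the compounds shown alone.

Measured compounds:
compound 1 `CCN(CC)c1ccc(NC(=O)c2cn(Cc3c(F)cccc3F)c3ccc(=O)[nH]c3c2=O)cc1` — 46 nM
compound 2 `Nc1ccc(NC(=O)c2cn(Cc3c(F)cccc3F)c3ccc(=O)[nH]c3c2=O)cc1` — 104 nM
compound 3 `O=C(Nc1c(F)cccc1F)c1cn(Cc2c(F)cccc2F)c2ccc(=O)[nH]c2c1=O` — > 1000 nM

The three compounds share one core and differ only in the aryl group on the amide-type nitrogen. In an in vitro assay on Sf21 cells for inhibition of high affinity 3',5'-cyclic-AMP phosphodiesterase 7A (Homo sapiens), read by scintillation proximity assay, with a stated time of 30 min (a higher number here means a weaker inhibitor, a lower number a stronger inhibitor), compound 1 gives 46 nM and compound 2 gives 104 nM, a change of a 2.3-fold higher number from compound 1 to compound 2 (0.35 log units; beyond the scatter). For compound 3 the read-out is only a limit of the assay, > 1000 nM, which is the limit of > 1000 nM in this assay, at which 1 of the 3 values shown sits; no number is known for it, so compound 3 stands at the weak end of what has been measured.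

Compound 4 `NS(=O)(=O)c1ccc(NC(=O)c2cn(Cc3c(F)cccc3F)c3ccc(=O)[nH]c3c2=O)cc1` is not yet measured. Its change from compound 3 is 4-sulfamoylphenyl in place of 2,6-difluorophenyl on an amide-type nitrogen.

Within the data shown here, the steps that bear on this change run the other way: an at least 21-fold higher number from compound 1 to compound 3 (1.33 log units; beyond the scatter) and an at least 9.6-fold higher number from compound 2 to compound 3 (0.98 log units; beyond the scatter), both beyond the scatter. Both measured compounds carrying a 4-substituted phenyl on the amide-type nitrogen give numbers, while the 2,6-difluorophenyl gives only a limit. Among the measured compounds shown here, compound 4 keeps a 4-substituted phenyl, so a lower number is expected in this assay, though the 4-sulfamoylphenyl itself has no measured precedent here.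

Compound 4 is estimated at 200 nM, within 50 nM to 900 nM. That estimate means a step of an at least 5.0-fold lower number from compound 3 to compound 4 (0.69 log units; beyond the scatter), expected as a lower number.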

Compound 4, half-maximal inhibitory concentration: 34 nM
Estimate against measurement, compound 4: 5.9-fold (0.77 log units) above, and the stated range ends above it.
By their numbers in this assay, from the lowest: compounds 4 and 1 (each within the scatter of the next); then compound 2. At a limit, above all of these: compound 3.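

In this assay, replacing the 2,6-difluorophenyl with a 4-sulfamoylphenyl on the amide-type nitrogen gives an at least 29-fold lower number from compound 3 to compound 4 (1.46 log units; beyond the scatter), so a third 4-substituted phenyl now gives a measured number, and this one carries a sulfamoyl group rather than an amine. As far as these compounds go, compound 3 remains only a limit of the assay, so the true size of that step is unknown: the limit of > 1000 nM in this assay, at which 1 of the 4 values shown sits. Among the 4-substituted phenyls, sulfamoyl in place of amino gives a 3.1-fold lower number from compound 2 to compound 4 (0.49 log units; beyond the scatter), while sulfamoyl in place of diethylamino gives a 1.4-fold lower number from compound 1 to compound 4 (0.13 log units; within the scatter), so compound 4 and compound 1 cannot be told apart here even though their substituents share little beyond the ring they sit on.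

From the compounds shown here alone, what remains open is whether the large step reflects the gain of the sulfamoyl group or the loss of the two fluorines, a question that an unsubstituted phenyl or a 4-fluorophenyl on the same amide-type nitrogen would address. Going by these compounds, it is also open how far the result extends to related groups at the same place on the ring, such as methylsulfonyl, a carboxylic acid or an N-methylsulfamoyl group.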